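Fluoro in Place of Trifluoromethyl: An Expected Gain

The compounds below may be only part of what the source reports. "The series", "measured", "known", "first", "only" and "open" are said of these compounds alone.

The study compares three measured compounds in an assay on V79 cells for inhibition of cytochrome P450 11B1, mitochondrial (Homo sapiens), read by HTRF, with a stated time of 1 h; on this read-out lower numbers stand for stronger inhibition and higher numbers for weaker inhibition. Compound 1, `FC(F)(F)c1ccc2c(c1)nc(-c1cccnc1)n2C1CC1`, carries a trifluoromethyl group on its core. In this assay compound 1 gives > 10000 nM, which is a limit of the assay rather than a number. Compound 1 thus stands at the limit of > 10000 nM in this assay, at which 1 of the 3 values shown sits. Compound 2, `Cn1c(-c2cccnc2)nc2ccc(F)cc21`, gives 677 nM in this assay. Compound 3, `Cc1ccncc1-c1nc2cc(F)c(F)cc2n1C1CC1`, gives 723 nM in this assay, and the values of compound 2 and compound 3 lie within the usual scatter of each other.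

Compound 4, `Fc1ccc2c(c1)nc(-c1cccnc1)n2C1CC1`, has not yet been measured. It differs from compound 1 in a single place: fluoro in place of trifluoromethyl on an aromatic carbon. Going by the values given here, no measured pair differs in exactly this way, so no measured step can be pointed to directly. What the numbers do show is that compound 2 and compound 3, both carrying fluoro, give values well inside the measurable range, while compound 1, carrying trifluoromethyl, stands at the limit of > 10000 nM in this assay, at which 1 of the 3 values shown sits. On that basis a large step toward stronger inhibition is expected, an at least 12-fold lower number from compound 1 to compound 4 (1.09 log units; beyond the scatter), well beyond the scatter. Compound 4 is estimated to give 800 nM in this assay, with an expected range from 200 nM to 4000 nM.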

Compound 4, half-maximal inhibitory concentration: 3980 nM
Estimate against measurement, compound 4: 5.0-fold (0.70 log units) below; the measured number falls inside the stated range.
By their numbers in this assay, from the lowest: compounds 2 and 3 (each within the scatter of the next); then compound 4. At a limit, above all of these: compound 1.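

In this assay, the exchange of trifluoromethyl for fluoro on this aromatic carbon, with the rest of the structure unchanged, now has a measured step of its own: an at least 2.5-fold lower number from compound 1 to compound 4 (0.40 log units; beyond the scatter). Going by these compounds alone, the earlier compounds held no pair that differed in this one place, so this is the first direct reading of the change, and it shows that the group at this position alone can move the read-out by more than the usual scatter, with compound 4 at 3980 nM, a value inside the measurable range. The full size of the step stays unknown, as the printed size is only a floor and compound 1 remains a limit of the assay and not a number: the limit of > 10000 nM in this assay, at which 1 of the 4 values shown sits.

The compounds shown leave open how a nitrile, a methoxy group or an amine on the same aromatic carbon would compare with fluoro and trifluoromethyl. Within the data shown here, they also leave open whether the same exchange gives a step of similar size on another core or at another carbon of this one, as this single pair is the only reading of it here.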